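Bromo for acetyl on the shared core: compound 4

A few compounds are considered here, and "the series" means these few. Any claim that something is new, unique, unknown or untested is made for them only; others in the source may bear on it.

Measured so far in a functional assay on the whole organism with Rattus norvegicus as the target, with a stated time of 4 h, at a dose of 40 mg/kg by the intraperitoneal route; on this read-out lower numbers stand for less inhibition and higher numbers for more inhibition at the one dose given (going by the name of the read-out):
- compound 1, `Cc1nc2c(COc3ccccc3)cccn2c1C`: 48%
- compound 2, `Cc1nc2c(CSc3ccccc3)cccn2c1C`: 29%
- compound 3, `CC(=O)c1c(C)nc2c(OCc3ccccc3)cccn12`: 57%

Compound 3 carries the highest number of the three. Its distance to compound 1 lies within the scatter, so the two cannot be ranked against each other; its distance to compound 2 lies beyond the scatter, so compound 3 does read as more inhibiting than compound 2. For the measured compounds named here, no two of the measured compounds differ in one place only, so no single step can be traced among them.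

Compound 4, `Cc1nc2c(OCc3ccccc3)cccn2c1Br`, is not yet measured. Set against compound 3 it shows (bromo in place of acetyl on an aromatic carbon). Going by the values given here, nothing among the measured compounds speaks to this exchange, so the expectation rests on compound 3 alone, with the numbers of compound 1 and compound 2 as the span seen so far in this assay. The step from compound 3 to compound 4 is expected to be small, about a number 10 percentage points lower from compound 3 to compound 4 (within the scatter), that is none beyond the scatter, leaning if anything slightly lower. Compound 4 is therefore estimated at 47% in this assay, with a range from 25% to 68%.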

Compound 4, a percentage reported as inhibition, in the whole organism at one dose (the size of the read-out at that dose, not a potency): 26%
Compound 4: the middle estimate sits 21 percentage points above what was measured; the measured number falls inside the stated range.
By their numbers in this assay, from the lowest: compounds 4 and 2 (each within the scatter of the next); then compounds 1 and 3 (each within the scatter of the next).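

In this assay, for the compounds shown here, exchanging acetyl for bromo on the aromatic carbon of the five-membered ring gives the first step that can be read at a single place: a number 31 percentage points lower from compound 3 to compound 4 (beyond the scatter), a large change. Going by these compounds alone, this place on the shared core is therefore not indifferent to its substituent: with the rest of the structure held constant, the read-out at the one dose follows the group there, and the acetyl-bearing compound 3 is the one that reads higher. The change replaces a group of 3 heavy atoms carrying a carbonyl and a hydrogen-bond acceptor with a single bromine atom, but no measurement at hand ties the step to any of these features.

From the compounds shown here alone, with only acetyl and bromo compared at this place, it remains open whether the higher number goes with the carbonyl or with acetyl as a whole, and how an amine, a carboxylic acid or a longer acyl chain such as butanoyl would read there. A single dose also leaves open whether the step would hold at other doses or reflects a difference in potency.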